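Removing the Methoxy Group from an Indole Acrylonitrile Series

The source may hold more compounds than are shown below. What is called first, only, known or untested is meant among the compounds shown, and "the series" means these compounds.

Measured compounds:
Compound 1, `COc1ccc(-c2[nH]c3ccccc3c2/C=C(\C#N)S(=O)(=O)c2ccccc2)cc1`, 1200 nM
Compound 2, `COc1ccc2[nH]c(-c3ccccc3)c(C=C(C#N)C#N)c2c1`, 6600 nM
Compound 3, `CCOC(=O)C(=Cc1c(-c2ccccc2)[nH]c2ccccc12)C(=O)OCC`, 12900 nM

In a functional assay on 786-0 cells (Homo sapiens) for inhibition, read by sulforhodamine B assay, with a stated time of 48 h (on this read-out lower numbers stand for stronger inhibition of growth and higher numbers for weaker inhibition of growth), compound 1 gives 1200 nM, the lowest of the three numbers; the nearest is compound 2 with 6600 nM, and the furthest is compound 3 with 12900 nM, both gaps lying beyond the scatter. Compound 4, `N#C/C(=C\c1c(-c2ccccc2)[nH]c2ccccc12)S(=O)(=O)c1ccccc1`, has not yet been measured in this assay. It differs from compound 1 by hydrogen in place of methoxy on an aromatic carbon, so that the 4-methoxyphenyl of compound 1 becomes a plain phenyl. Among the measured compounds shown here, no pair of measured compounds shows this change on its own, so its size is unknown here. Compounds 2 and 3 carry a plain phenyl on the shared core but also other acceptor groups, so their values alone cannot isolate the effect. A modest weakening of growth inhibition is expected, with a step of a 2.1-fold higher number from compound 1 to compound 4 (0.32 log units; beyond the scatter), though a step within the scatter cannot be ruled out. Compound 4 is therefore estimated at 2500 nM, within a range from 800 nM to 8000 nM.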

Compound 4, concentration for 50% growth inhibition: 9200 nM
For compound 4 the middle estimate is 3.7-fold (0.57 log units) below the measured one; the whole stated range lies below it.
By their numbers in this assay, from the lowest: compound 1; then compounds 2, 4 and 3 (each within the scatter of the next).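

In this assay, among the compounds shown here, hydrogen in place of methoxy now has a measured size of its own, which the earlier compounds could not give: the change from 4-methoxyphenyl to phenyl produces a 7.7-fold higher number from compound 1 to compound 4 (0.88 log units; beyond the scatter) on an otherwise unchanged structure. The low number of compound 1 at 1200 nM is therefore not carried by the shared core and the phenylsulfonyl and nitrile groups alone, since compound 4 keeps all of these and gives 9200 nM without the methoxy para to a large group. Nothing available here accounts for the size of this step. The compounds shown leave open what other groups at this place would do, for instance a hydroxyl, an amine or a longer chain such as ethoxy, and whether any of them would match or go beyond the methoxy of compound 1. They also leave open whether the same change would give a step of similar size with the two ethyl ester groups of compound 3 in place of the phenylsulfonyl and nitrile groups.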